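The source may report more compounds than this note shows. Statements on the series, on what has been measured and on what is new or still open speak of the compounds shown alone.

Compound 1 `NC1=NC2(CCOCC2)N(OCCCOc2cccc(Cl)c2Cl)C(N)=N1`: 5 nM
Compound 2 `NC1=NC2(CCSCC2)N(OCCCOc2ccccc2Cl)C(N)=N1`: 1 nM

Both values come from a functional assay on HCT-116 cells (Homo sapiens) for antiproliferative activity, read by MTT assay, with a stated time of 72 h; a higher number here means a weaker inhibitor, a lower number a stronger inhibitor. Of the two, compound 1 stands at the higher number, and its distance to compound 2 lies beyond the scatter. Compound 3 `Cc1ccc(OCCCON2C(N)=NC(N)=NC23CCOCC3)cc1` differs from compound 1 in one place: 4-methylphenyl in place of 2,3-dichlorophenyl on an oxygen on a saturated carbon. Among the compounds with values here, no measured pair shows this change, so its direction rests on inference alone; both measured compounds bear chlorine, whereas compound 3 bears none. A modest upward step a 4.0-fold higher number from compound 1 to compound 3 (0.60 log units; beyond the scatter) is expected. For compound 3 the estimated value in this assay is 20 nM, within a range from 4 nM to 100 nM.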

Compound 3, half-maximal inhibitory concentration: 2390 nM
Compound 3: the middle estimate sits 120-fold (2.08 log units) below what was measured; the whole stated range lies below it.
By their numbers in this assay, from the lowest: compound 2; then compound 1; then compound 3.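

With 4-methylphenyl in place of 2,3-dichlorophenyl on an oxygen on a saturated carbon, this assay gives a 480-fold higher number from compound 1 to compound 3 (2.68 log units; beyond the scatter). The earlier compounds shown here offered no step at this position; this pair shows that it is highly sensitive to the group it carries. Nothing shown explains the size of this step. Because the chlorines leave and the methyl enters in the same change, the pair cannot separate their contributions. As far as these compounds go, how unsubstituted phenyl or 4-chlorophenyl would stand on the core of compound 1 remains open.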